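Methoxy step repeated across two linker lengths

This account rests on a few compounds, and the source may have more. Where it says the series, first, only, none or still open, it means among the compounds named here.

Compound 1 `O=C(CCCCC1CCSS1)NCc1cn(CCCOc2ccc3cc(-c4ccccc4)c(=O)oc3c2)nn1` gives 27.2% in a functional assay on PC-12 cells (Rattus norvegicus) for cytotoxicity, read by MTT assay, with stated times of 3 h and 2 h, tested at 20 uM; on this read-out lower numbers stand for a weaker effect and higher numbers for a stronger effect at the one concentration tested. Compound 2 `COc1ccc(-c2cc3ccc(OCCCn4cc(CNC(=O)CCCCC5CCSS5)nn4)cc3oc2=O)cc1` carries methoxy in place of hydrogen on an aromatic carbon and gives 62%, a step that reads a number 34.8 percentage points higher from compound 1 to compound 2 (beyond the scatter). Compound 3 `O=C(CCCCC1CCSS1)NCc1cn(CCCCOc2ccc3cc(-c4ccccc4)c(=O)oc3c2)nn1` gives 26%; the difference between the cores of compound 1 and compound 3 is not broken down here, and the two values lie within the scatter of each other. Compound 4 `COc1ccc(-c2cc3ccc(OCCCCn4cc(CNC(=O)CCCCC5CCSS5)nn4)cc3oc2=O)cc1` is not yet measured; it differs from compound 3 by methoxy in place of hydrogen on an aromatic carbon, the same change that was made from compound 1 to compound 2, so that this change occurs twice among the compounds shown. Among the measured compounds shown here, the step from compound 3 to compound 4 is expected to be of similar size, which rests on the single step of a number 34.8 percentage points higher from compound 1 to compound 2 (beyond the scatter) seen in this assay. Compound 4 is therefore estimated at 58%, a step of a number 32 percentage points higher from compound 3 to compound 4 (beyond the scatter). The range expected for compound 4 runs from 40% to 75%.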

Compound 4, a percentage reported as activity, at one concentration (the size of the read-out at that concentration, not a potency): 52.3%
Estimate against measurement, compound 4: 5.7 percentage points above; low and high end bracket the measured number.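

Phenyl to 4-methoxyphenyl carries over to the second core in this assay, giving a number 26.3 percentage points higher from compound 3 to compound 4 (beyond the scatter). The two steps agree in size: the same change on two cores in this assay, a number 34.8 percentage points higher (beyond the scatter) from compound 1 to compound 2 and a number 26.3 percentage points higher (beyond the scatter) from compound 3 to compound 4, 8.5 percentage points apart, within the scatter of two such steps This shows transfer between these two cores only, on two pairs of compounds at one concentration, and it does not show that the step would hold on a core further removed, or why the methoxy group raises the read-out.

The compounds shown leave open whether an amine, a hydroxyl or a chlorine in the same place would shift the read-out as methoxy does. On these data alone, whether a longer chain in the core would preserve the step also remains open, as does the size of the effect at any other concentration.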